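This account rests on a few compounds, and the source may have more. Where it says the series, first, only, none or still open, it means among the compounds named here.

Working notes on the series in a functional assay on NCI-H460 cells (Homo sapiens) for antiproliferative activity, read by MTT assay, with a stated time of 48 h; on this read-out higher numbers stand for weaker inhibition and lower numbers for stronger inhibition. The compounds with a third sugar give numbers: compound 1 `CCCCCCCCO[C@@H]1O[C@@H](C)[C@H](OC(=O)CCCCC)[C@@H](O[C@@H]2O[C@@H](C)[C@H](OC(C)=O)[C@@H](O[C@@H]3O[C@@H](C)[C@H](O)[C@@H](O)[C@H]3OC(C)=O)[C@H]2OC(C)=O)[C@H]1O` gives 24000 nM, and compound 2 `CCCCCCCCO[C@@H]1O[C@@H](C)[C@H](OC(=O)CCCCC)[C@@H](O[C@@H]2O[C@@H](C)[C@H](OC(C)=O)[C@@H](O[C@@H]3O[C@@H](C)[C@H](OC(C)=O)[C@@H](OC(C)=O)[C@H]3O)[C@H]2OC(C)=O)[C@H]1O` gives 10000 nM. Compound 3 `CCCCCCCCO[C@@H]1O[C@@H](C)[C@H](OC(=O)CCCCC)[C@@H](O[C@@H]2O[C@@H](C)[C@H](OC(C)=O)[C@@H](O)[C@H]2OC(C)=O)[C@H]1O` has only two sugars, and for compound 3 this assay reports only a limit, > 500000 nM, so compound 3 stands at the weak end of what is shown; this is the point noted as the limit of > 500000 nM in this assay, at which 1 of the 3 values shown sits. Compound 4 `CCCCCCCCO[C@@H]1O[C@@H](C)[C@H](OC(=O)CCCCC)[C@@H](O[C@@H]2O[C@@H](C)[C@H](OC(C)=O)[C@@H](OC(C)=O)[C@H]2OC(C)=O)[C@H]1O` differs from compound 3 by acetyl in place of hydrogen on an oxygen on a saturated carbon. Going by the values given here, compound 2 against compound 1 shows that a free hydroxyl capped by acetyl went with a stronger value, but those two also differ elsewhere, so no direct step is drawn. For compound 4 a step of an at least 2.0-fold lower number from compound 3 to compound 4 (0.30 log units; that floor lies within the scatter) is expected, likely still weak, estimated at 250000 nM with a range from 60000 nM to 800000 nM.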

Compound 4, half-maximal inhibitory concentration: 15000 nM
Estimate against measurement, compound 4: 17-fold (1.22 log units) above, and the stated range ends above it.
By their numbers in this assay, from the lowest: compounds 2, 4 and 1 (each within the scatter of the next, the first and the last beyond it). At a limit, above all of these: compound 3.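

In this assay, going by these compounds alone, hydroxy to acetoxy on this oxygen is the only single-place change, and it gives an at least 33-fold lower number from compound 3 to compound 4 (1.52 log units; beyond the scatter). A free hydroxy here goes with no numerical value, whereas acetoxy alone is enough to give compound 4 a measured number. The true size of the step stays unknown, because compound 3 is reported only as a limit: the limit of > 500000 nM in this assay, at which 1 of the 4 values shown sits.

As far as these compounds go, it remains open whether acetyl specifically is needed on this oxygen, or whether a longer acyl chain, a methyl ether or an amine in its place would serve as well. Also open, from the compounds shown here alone, is how this change would read on a compound with a third sugar.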